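Moving the Amine One Bond Out on the Saturated Ring

The source may report more compounds than this note shows. Statements on the series, on what has been measured and on what is new or still open speak of the compounds shown alone.

Measured so far in an assay on isolated protein for inhibition of DNA topoisomerase 1 (Homo sapiens), with a stated time of 15 min; on this read-out lower numbers stand for stronger inhibition and higher numbers for weaker inhibition:
compound 1, `COc1c(N2CC[C@@H](CO)C2)c(F)cc2c(=O)c(C(=O)O)cn(Cc3ccc(-c4ccccc4)cc3)c12`: > 200000 nM
compound 2, `CN[C@@H]1CCN(c2c(F)cc3c(=O)c(C(=O)O)cn(Cc4ccc(-c5ccccc5)cc4)c3c2OC)C1`: 57700 nM

The value of compound 1 is a limit of the assay, not a number (the limit of > 200000 nM in this assay, at which 1 of the 2 values shown sits). Among the compounds with values here, compound 2 is therefore the only compound with a measured number, and the step of an at least 3.4-fold lower number from compound 1 to compound 2 (0.53 log units; beyond the scatter) shows that methylamino in place of hydroxymethyl on a saturated ring carbon moved the read-out in the favourable direction.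

Compound 3, `COc1c(N2CC[C@@H](CN)C2)c(F)cc2c(=O)c(C(=O)O)cn(Cc3ccc(-c4ccccc4)cc3)c12`, differs from compound 2 by aminomethyl in place of methylamino on a saturated ring carbon. No measured step covers this rearrangement; the one step shown concerns a different exchange on the same ring carbon and speaks only to the presence of the amine nitrogen, which compound 3 keeps. A step of no more than modest size in either direction is therefore expected, with some chance that this assay again reports only a limit. The estimate for compound 3 is 90000 nM, within 30000 nM to 250000 nM, an expected step of a 1.6-fold higher number from compound 2 to compound 3 (0.19 log units; within the scatter).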

Compound 3, half-maximal inhibitory concentration: 26000 nM
Estimate against measurement, compound 3: 3.5-fold (0.54 log units) above; measured number outside the range, below it.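

With the same atoms joined differently, the change from 3-(methylamino)pyrrolidin-1-yl to 3-(aminomethyl)pyrrolidin-1-yl gave a 2.2-fold lower number from compound 2 to compound 3 (0.35 log units; beyond the scatter) in this assay, so this ring carbon responds to where the nitrogen stands and not only to whether one is present. Amino in place of hydroxy on the chain carbon gave an at least 7.6-fold lower number from compound 1 to compound 3 (0.88 log units; beyond the scatter), a comparison in which the side chain keeps its length and only its end group changes. Compound 1 gives a limit of the assay, not a number: the limit of > 200000 nM in this assay, at which 1 of the 3 values shown sits.

As far as these compounds go, whether a longer chain such as aminoethyl on this ring carbon would continue the direction seen with aminomethyl remains open. Also open, from the compounds shown here alone, is how a dimethylamino group or a carboxylic acid would read at the same place.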